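From Hydroxyphenyl to Fluoromethoxyphenyl in a Cytotoxicity Test

The source may report more compounds than this note shows. Statements on the series, on what has been measured and on what is new or still open speak of the compounds shown alone.

- Compound 1 `CCOC(=O)CCCCCOc1cccc(CN(C(=O)c2ccc(-c3cccc4ccccc34)cc2)C(C)C)c1`: > 26000 nM, a limit
- Compound 2 `CCOC(=O)CCCCCOc1cccc(CN(C(=O)c2ccc(-c3cccc(O)c3)cc2)C(C)C)c1`: > 26000 nM, a limit

In an ADME assay on BJ cells (Homo sapiens) for cytotoxicity, read by CellTiter-Glo and resazurin assay, with a stated time of 72 h (on this read-out higher numbers stand for an effect only at larger amounts of compound and lower numbers for an effect already at smaller amounts), compound 2 gives > 26000 nM, which is a limit and not a number. Neither measured compound has a readable number, and the record holds only (the limit of > 26000 nM in this assay, at which 2 of the 2 values shown sit).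

Compound 3 `CCOC(=O)CCCCCOc1cccc(CN(C(=O)c2ccc(-c3cc(OC)ccc3F)cc2)C(C)C)c1` carries 2-fluoro-5-methoxyphenyl in place of 3-hydroxyphenyl on an aromatic carbon. Among the measured compounds shown here, the one measured step at this kind of place is a step that the two limits leave unreadable from compound 1 to compound 2, where 3-hydroxyphenyl replaced naphthalen-1-yl. Its size cannot be read, but neither group gave a result short of the limit. No step beyond the usual scatter is therefore expected in this assay, in either direction, and the estimated step is a number no higher from compound 2 to compound 3 (the limit leaves the size open). For compound 3 the expected value is 26000 nM, with an estimated range of 12000 nM to 40000 nM.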

Compound 3, half-maximal effective concentration: > 26000 nM
Compound 3: no number, only a limit; the forecaster's own chance of this, stated with the estimate: 85%; the middle value lies on the limit itself.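

No step can be read among compound 1, compound 2 and compound 3: the limit of > 26000 nM in this assay, at which 3 of the 3 values shown sit.

The compounds shown leave open how these three groups compare in this assay, and whether any group at this place would give a readable number there.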